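A few compounds are considered here, and "the series" means these few. Any claim that something is new, unique, unknown or untested is made for them only; others in the source may bear on it.

Compound 1, `CC(=O)Nc1ccc(C2=NNC(=O)CC2)cc1`, in a functional assay for inhibition, with Homo sapiens as the target; on this read-out lower numbers stand for an effect already at smaller amounts and higher numbers for an effect only at larger amounts of compound: 1 ug/mL
Compound 2, `CC(=O)Nc1ccc(C2=NN(C)C(=O)CC2)cc1`, in this assay: > 46.4 ug/mL
Compound 3, `CC(=O)Nc1ccc(C2=NNC(=O)C(C)C2)cc1`, in this assay: 46.4 ug/mL

Of the two numbers given in this assay, compound 1 stands lowest; its nearest neighbour is compound 3, reached by a 46-fold higher number from compound 1 to compound 3 (1.67 log units; beyond the scatter). The value of compound 2 is a limit of the assay, not a number, and compound 2 sits at the limit of > 46.4 ug/mL in this assay, at which 1 of the 3 values shown sits. Counted as a step, this is an at least 46-fold higher number from compound 1 to compound 2 (1.66 log units; beyond the scatter).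

Compound 4, `CCC(C)NCC(=O)Nc1ccc(C2=NNC(=O)CC2)cc1`, differs from compound 1 by (sec-butyl)amino in place of hydrogen on a saturated chain carbon bound to a carbonyl carbon. Neither measured step touches this place: both measured changes sit on the ring of the shared core, and both were large and in the direction of higher numbers. For the measured compounds named here, no measured step bears directly on the change to compound 4, so the expectation rests on compound 1 alone, with only a loose allowance for the fact that every change tried so far has raised the number. Compound 4 is therefore expected to give a step of a 3.0-fold higher number from compound 1 to compound 4 (0.48 log units; beyond the scatter), and compound 4 is estimated at 3 ug/mL, within a range from 0.5 ug/mL to 20 ug/mL.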

Compound 4, half-maximal effective concentration: about 21.5 ug/mL
Estimate against measurement, compound 4: 7.2-fold (0.86 log units) below; the measured number lies above the stated range.
By their numbers in this assay, from the lowest: compound 1; then compound 4; then compound 3.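

In this assay, for the compounds shown here, the earlier steps touched only the ring of the shared core, whereas this one places (sec-butyl)amino in place of hydrogen on a saturated chain carbon bound to a carbonyl carbon, and it still gives a 22-fold higher number from compound 1 to compound 4 (1.33 log units; beyond the scatter). The sensitivity of this read-out is therefore not confined to that ring: among the compounds shown, each single change from compound 1 raises the number, and none goes against this, so this chain carbon is also a place where a substituent can cost much of the effect. Nothing shown explains why this group at this place raises the number.

The compounds shown leave open whether the rise belongs to the nitrogen itself or to the sec-butyl group it carries, since only this one substituent stands at this place. A plain amino group, a dimethylamino group, a methoxy group or a single methyl on the same carbon would separate these readings and show whether any group there can keep the number near that of compound 1.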